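The source may hold more compounds than are shown below. What is called first, only, known or untested is meant among the compounds shown, and "the series" means these compounds.

Measured so far in a functional assay, with a stated time of 10 min; a lower number here means a stronger inhibitor, a higher number a weaker inhibitor:
- compound 1 `O=c1cc(/C=C/c2ccccc2)[nH]cc1O` gives 4030 nM
- compound 2 `O=c1cc(/C=C/c2ccc(Cl)cc2)[nH]cc1O` gives 11500 nM

Compound 2 holds the higher of these two numbers. The next structure is compound 3 `CN(C)c1ccc(/C=C/c2cc(=O)c(O)c[nH]2)cc1`, with dimethylamino in place of chloro on an aromatic carbon, para to a large group dimethylamino in place of chloro on an aromatic carbon in the change. Going by the values given here, one measured step bears on this place: chloro in place of hydrogen gave a 2.9-fold higher number from compound 1 to compound 2 (0.46 log units; beyond the scatter), a modest change. Among the compounds with values here, no measured compound carries dimethylamino, so the expectation is loose: a modest move to a lower number. The estimated step is a 1.9-fold lower number from compound 2 to compound 3 (0.28 log units; within the scatter) in this assay. For compound 3 the expected value is 6000 nM (range 1800 nM to 20000 nM) .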

Compound 3, half-maximal inhibitory concentration: 3410 nM
The estimate for compound 3 lay 1.8-fold (0.25 log units) above the measured number; low and high end bracket the measured number.
By their numbers in this assay, from the lowest: compounds 3 and 1 (each within the scatter of the next); then compound 2.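

In this assay, dimethylamino at this place on the aromatic carbon gives a clearly lower number than chloro: a 3.4-fold lower number from compound 2 to compound 3 (0.53 log units; beyond the scatter). Against hydrogen it shows no separable change, a 1.2-fold lower number from compound 1 to compound 3 (0.07 log units; within the scatter), so the position accepts dimethylamino without loss, and of the two groups tried only chloro raises the number. No measurement available here accounts for the difference between chloro and dimethylamino.

Still open, as far as these compounds go, is whether a methoxy group, a primary amine or a carboxylic acid at this place would track hydrogen and dimethylamino or track chloro.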